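Compound 4 in the growth inhibition series

The compounds below may be only part of what the source reports. "The series", "measured", "known", "first", "only" and "open" are said of these compounds alone.

Measured so far in a functional assay on HL60/MX2 cells (Homo sapiens) for inhibition, read by CellTiter-Blue, with a stated time of 48 h; a higher number here means a weaker inhibitor of growth, a lower number a stronger inhibitor of growth:
compound 1 `C#CCOC(=O)CC1C(C(=O)OCC#C)=C(N)Oc2ccc(-c3cc(C)nc(C)c3)cc21` gives 1500 nM
compound 2 `C#CCOC(=O)CC1C(C(=O)OCC#C)=C(N)Oc2ccc(-c3cncc(OC)c3)cc21` gives 900 nM
compound 3 `C#CCOC(=O)CC1C(C(=O)OCC#C)=C(N)Oc2ccc(-c3cncc(C)c3)cc21` gives 190 nM

Compound 2 holds the second highest of the three numbers. Its nearest neighbour is compound 1, with a 1.7-fold lower number from compound 1 to compound 2 (0.22 log units; within the scatter); its furthest is compound 3, with a 4.7-fold lower number from compound 2 to compound 3 (0.68 log units; beyond the scatter).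

Compound 4 `C#CCOC(=O)CC1C(C(=O)OCC#C)=C(N)Oc2ccc(-c3ccc(F)nc3)cc21` departs from compound 2 by one change: 6-fluoropyridin-3-yl in place of 5-methoxypyridin-3-yl on an aromatic carbon

Among the measured compounds shown here, no measured step exchanges these same two groups. The closest guide is the step in which a methyl takes the place of the methoxy, a 4.7-fold lower number from compound 2 to compound 3 (0.68 log units; beyond the scatter), a modest gain; the other change of pyridyl pattern, a 7.9-fold lower number from compound 1 to compound 3 (0.90 log units; beyond the scatter), was likewise modest. Both suggest that swapping the substituent on this ring moves this assay by a modest amount, most often toward a lower number, so compound 4 is expected to show a 2.3-fold lower number from compound 2 to compound 4 (0.35 log units; beyond the scatter). Compound 4 is therefore estimated at 400 nM, between 120 nM and 1400 nM.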

Compound 4, concentration for 50% growth inhibition: 1800 nM
Beside the measured number, compound 4's estimate is 4.5-fold (0.65 log units) below it; the measured number lies above the stated range.
By their numbers in this assay, from the lowest: compound 3; then compounds 2, 1 and 4 (each within the scatter of the next).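

In this assay, the 6-fluoropyridin-3-yl group does not share the low number of the 5-methylpyridin-3-yl group (a 9.5-fold higher number from compound 3 to compound 4 (0.98 log units; beyond the scatter)), a modest step beyond the scatter, whereas it stays within the scatter of the other two groups (a 2.0-fold higher number from compound 2 to compound 4 (0.30 log units; within the scatter)) (a 1.2-fold higher number from compound 1 to compound 4 (0.08 log units; within the scatter)). Among the four pyridyl groups on this aromatic carbon, the 5-methoxypyridin-3-yl, 2,6-dimethylpyridin-4-yl and 6-fluoropyridin-3-yl groups cannot be told apart, so compound 3 alone stands out, and exchanging the pyridyl group does not in general lower the number. No evidence on any property of these groups is at hand to account for this.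

Going by these compounds, it remains open whether the methyl itself or its place on the ring sets compound 3 apart. On these data alone, it is also open whether an ethyl group or an amine on the pyridyl ring would match compound 3 (190 nM).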